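Swapping the sulfur substituent on a nucleoside inhibitor

This account rests on a few compounds, and the source may have more. Where it says the series, first, only, none or still open, it means among the compounds named here.

Compound 1 `CCCCCNc1ncnc2c1ncn2[C@@H]1O[C@H](CO)[C@@H](O)[C@H]1O` gives 13500 nM in an assay on isolated protein for binding affinity to Equilibrative nucleoside transporter 1 (Homo sapiens); on this read-out higher numbers stand for weaker inhibition and lower numbers for stronger inhibition.
Compound 2 `OC[C@H]1O[C@@H](n2cnc3c(Sc4ccccc4)ncnc32)[C@H](O)[C@@H]1O` gives 91200 nM in this assay.
Compound 3 `Nc1nc(SCc2ccc(F)cc2)c2ncn([C@@H]3O[C@H](CO)[C@@H](O)[C@H]3O)c2n1` gives 1150 nM in this assay.

Among these three, compound 3 has the lowest number, and both gaps lie beyond the scatter: compound 1 stands nearest, compound 2 furthest. Compound 4 `CC(=O)c1cc(Cl)ccc1Sc1nc(N)nc2c1ncn2[C@@H]1O[C@H](CO)[C@@H](O)[C@H]1O` has not yet been measured. It differs from compound 3 in one place: 2-acetyl-4-chlorophenyl in place of 4-fluorobenzyl on a sulfur. For the measured compounds named here, the only measured step, a 6.8-fold higher number from compound 1 to compound 2 (0.83 log units; beyond the scatter), changes a substituent on an aromatic carbon of the shared core, not the group on the sulfur, so it bears only loosely on the present change; it shows that a sulfur-linked aromatic group can raise the number, but compound 3 carries a sulfur-linked group and still gives the lowest number here. Nothing measured tells how the 2-acetyl-4-chlorophenyl group compares with the 4-fluorobenzyl group. The expectation is therefore a modest move, most likely toward a somewhat higher number, a 2.2-fold higher number from compound 3 to compound 4 (0.34 log units; beyond the scatter), with wide uncertainty. Compound 4 is estimated at 2500 nM, within 600 nM to 10000 nM.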

Compound 4, half-maximal inhibitory concentration: 14500 nM
Compound 4: middle estimate off by 5.8-fold (0.76 log units), on the low side; measured number outside the range, above it.
By their numbers in this assay, from the lowest: compound 3; then compounds 1 and 4 (each within the scatter of the next); then compound 2.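

The group on the sulfur clearly matters in this assay: putting 2-acetyl-4-chlorophenyl in place of 4-fluorobenzyl gives a 13-fold higher number from compound 3 to compound 4 (1.10 log units; beyond the scatter) and is the first step shown at this position, since the earlier step changed a substituent on an aromatic carbon. The swap makes several changes at once: a benzyl becomes a phenyl, the fluorine is lost, and a chlorine and an acetyl group arrive, so the step belongs to the whole change and not to any one of these parts. Nothing measured here explains why the number rises.

As far as these compounds go, it remains open whether a plain phenyl, or a phenyl carrying only the chlorine or only the acetyl, would read closer to compound 3 or to compound 4. From the compounds shown here alone, how an unsubstituted benzyl, a simple alkyl chain or a carboxylic acid on the sulfur would behave is also open.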